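The compounds below may be only part of what the source reports. "The series", "measured", "known", "first", "only" and "open" are said of these compounds alone.

Working notes on the series. Compound 1 `Nc1cc(-c2ccc(Br)cc2)nc2cc(-c3ccc(Cl)cc3)nn12` and compound 3 `Nc1cc(-c2ccc(Cl)cc2)nc2cc(-c3ccc(Br)cc3)nn12` share the same atoms joined differently; the difference between the two cores is not broken down here. In a functional assay on the whole organism (strain Wistar) for inhibition, with Rattus norvegicus as the target, read by paw edema, with stated times of 30 min and 3 h, at a dose of 50 mg/kg by the oral route (on this read-out higher numbers stand for more inhibition at the one dose given (going by the name of the read-out) and lower numbers for less inhibition), compound 1 gives 70.7%, and compound 3 gives 56.1%. Compound 2 `Cc1ccc(-c2cc3nc(-c4ccc(Br)cc4)cc(N)n3n2)cc1` carries the change methyl in place of chloro on an aromatic carbon on the core of compound 1; in this assay compound 2 gives 56.1%. The step of a number 14.6 percentage points lower from compound 1 to compound 2 (beyond the scatter) is beyond the scatter, while the values of compound 2 and compound 3 lie within it. Compound 4 `Cc1ccc(-c2cc(N)n3nc(-c4ccc(Br)cc4)cc3n2)cc1` carries the same change methyl in place of chloro on an aromatic carbon on the core of compound 3, with the place described in the same words for both pairs. For the measured compounds named here, for compound 4 a step of a number 14.1 percentage points lower from compound 3 to compound 4 (beyond the scatter) is expected in this assay, resting on the step of a number 14.6 percentage points lower from compound 1 to compound 2 (beyond the scatter), the only measured instance of this change. Compound 4 is accordingly estimated at 42%, between 28% and 55%.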

Compound 4, a percentage reported as inhibition, in the whole organism at one dose (the size of the read-out at that dose, not a potency): 73.2%
Compound 4: the middle estimate sits 31.2 percentage points below what was measured; the whole stated range lies below it.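

The change from 4-chlorophenyl to 4-methylphenyl reads a number 17.1 percentage points higher from compound 3 to compound 4 (beyond the scatter) in this assay. On these two cores the same change does not carry over, and its direction reverses: the same change on two cores in this assay, a number 14.6 percentage points lower (beyond the scatter) from compound 1 to compound 2 and a number 17.1 percentage points higher (beyond the scatter) from compound 3 to compound 4, 31.7 percentage points apart, beyond the scatter of two such steps. So a step measured on one of these cores is a poor guide to the other, but with one pair per core this does not show why the two steps part, nor how any other change would carry across.

Going by these compounds, it remains open whether an amine, a methoxy group or a carboxylic acid in place of chloro would also give opposite steps on the two cores. On these data alone, whether these steps would hold at another oral dose also remains open.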